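A Five-Membered Ring Replaces the Chlorophenyl Amide

The source may report more compounds than this note shows. Statements on the series, on what has been measured and on what is new or still open speak of the compounds shown alone.

Compound 1, `O=C(Nc1ccc(Cl)c(-c2nnc3c(Cl)cccn23)c1)c1c(F)cccc1Cl`, in a functional assay on MDA-MB-468 cells (Homo sapiens) for antiproliferative activity, read by MTT assay, with a stated time of 72 h; on this read-out higher numbers stand for weaker inhibition and lower numbers for stronger inhibition: 57600 nM
Compound 2, `O=C(Nc1ccc(Cl)c(-c2nnc3c(Cl)cccn23)c1)c1ccccc1Cl`, a limit of the assay: > 100000 nM
Compound 3, `O=C(Nc1ccc(Cl)c(-c2nnc3c(Cl)cccn23)c1)c1ccc(Cl)cc1`, a limit of the assay: > 100000 nM

All three share one core and differ only in the group on the carbonyl carbon of the amide. Compound 3 stands at the edge of what the assay can report: its value is a limit, not a number. This is the limit of > 100000 nM in this assay, at which 2 of the 3 values shown sit, so only compound 1 gives a number at all, and that number is high.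

Compound 4, `O=C(Nc1ccc(Cl)c(-c2nnc3c(Cl)cccn23)c1)c1ccon1`, keeps the core and changes the amide: 1,2-oxazol-3-yl in place of 4-chlorophenyl on a carbonyl carbon.

Two steps reach compound 3 and so touch the same position. One is an at least 1.7-fold higher number from compound 1 to compound 3 (0.23 log units; that floor lies within the scatter); the other is a step that the two limits leave unreadable from compound 2 to compound 3. Both exchange one substituted phenyl for another and both end at a limit, so neither shows what a five-membered ring with two hetero atoms does here. Among the compounds with values here, no measured step involves a 1,2-oxazol-3-yl.

With the measured steps all at or near the limit, compound 4 is expected to stay in the same weak region, a step of about a number no higher from compound 3 to compound 4 (the limit leaves the size open). Compound 4 is estimated at 100000 nM, with a range from 30000 nM to 300000 nM.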

Compound 4, half-maximal inhibitory concentration: > 100000 nM
Compound 4: a limit, no number (the forecaster's own chance of this, stated with the estimate: 65%); the middle value lies on the limit itself.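

In this assay, compound 4 gives only a limit of the assay, > 100000 nM, so a five-membered aromatic ring with 2 hetero atoms on this carbonyl carbon yields no readable number, just as the 2-chlorophenyl and 4-chlorophenyl groups did not. Within the data shown here, the one step that can be read is an at least 1.7-fold higher number from compound 1 to compound 4 (0.23 log units; that floor lies within the scatter), so even this comparison with the only compound that has a number does not establish a loss, and the steps that link compound 4 to compound 2 and compound 3 cannot be read, with limits at both ends. The position now holds two kinds of aromatic ring, and the series as a whole still sits at the edge of what the assay can report: the limit of > 100000 nM in this assay, at which 3 of the 4 values shown sit.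

The compounds shown leave open whether any group on this carbonyl carbon can give a clearly lower number, for instance a saturated ring amine such as piperidin-4-yl, a short chain carrying a carboxylic acid, or a larger fused aromatic ring such as quinolin-3-yl. They also leave open whether changes to the shared core, rather than to the amide, would bring the series into a range where steps of this kind can be measured.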